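A few compounds are considered here, and "the series" means these few. Any claim that something is new, unique, unknown or untested is made for them only; others in the source may bear on it.

Measured compounds: compound 1 `COCCNC(=O)[C@H]1CC[C@@H](Nc2ncc3c(Br)nn(-c4ccc5ncccc5c4)c3n2)C1` with 156 nM in an assay on SK-OV-3 cells for inhibition of eIF-2-alpha kinase GCN2 (Homo sapiens); on this read-out higher numbers stand for weaker inhibition and lower numbers for stronger inhibition; compound 2 `Brc1nn(-c2ccc3ncccc3c2)c2nc(N[C@@H]3CC[C@@H](c4ncc[nH]4)C3)ncc12` with 545 nM in this assay.

Of the two numbers, compound 2 holds the higher one, and the gap to compound 1 lies beyond the scatter. Compound 3 `CNC(=O)[C@@H]1CC[C@@H](Nc2ncc3c(Br)nn(-c4ccc5ncccc5c4)c3n2)C1` is reached from compound 2 by methylcarbamoyl in place of 1H-imidazol-2-yl on a saturated ring carbon. Going by the values given here, no measured pair shows this exact change, but compound 1, which also carries a carbamoyl group at that position, gives 156 nM. Compound 3 is therefore expected to move toward a lower number, with the step of a 2.7-fold lower number from compound 2 to compound 3 (0.44 log units; beyond the scatter) estimated to exceed the scatter. The estimate for compound 3 is 200 nM, within 70 nM to 600 nM.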

Compound 3, half-maximal inhibitory concentration: 25 nM
The estimate for compound 3 lay 8.0-fold (0.90 log units) above the measured number; the measured number lies below the stated range.
By their numbers in this assay, from the lowest: compound 3; then compound 1; then compound 2.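

In this assay the swap of 1H-imidazol-2-yl for methylcarbamoyl on this saturated ring carbon gives a 22-fold lower number from compound 2 to compound 3 (1.34 log units; beyond the scatter) and counts as a large step. The number therefore depends strongly on which group sits here, even though the two groups match in their counted hydrogen-bond donors and acceptors. Nothing available explains the size of this step.

Open, on these data alone, is how a carboxylic acid, an amine or an unsubstituted carbamoyl group would fare at this carbon. Also open, as far as these compounds go, is whether the methyl on the amide nitrogen contributes to the result.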